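This account rests on a few compounds, and the source may have more. Where it says the series, first, only, none or still open, it means among the compounds named here.

Measured compounds in a functional assay on HT-1080 cells (Homo sapiens) for antiproliferative activity, read by sulforhodamine B assay, with a stated time of 48 h; a lower number here means a stronger inhibitor, a higher number a weaker inhibitor:
- compound 1 `CC(=O)NS(=O)(=O)c1ccc(N/C(S)=N\c2ccnc3cc(C(F)(F)F)ccc23)cc1`: 28300 nM
- compound 2 `N=C(N)NS(=O)(=O)c1ccc(N/C(S)=N\c2ccnc3cc(C(F)(F)F)ccc23)cc1`: 24300 nM
- compound 3 `O=S(=O)(Nc1ccccn1)c1ccc(N/C(S)=N\c2ccnc3cc(C(F)(F)F)ccc23)cc1`: 28000 nM

Compound 3 stands second highest of the three numbers. Its nearest neighbour is compound 1 a 1.0-fold lower number from compound 1 to compound 3 (0.00 log units; within the scatter), and its furthest is compound 2 a 1.2-fold higher number from compound 2 to compound 3 (0.06 log units; within the scatter); both steps lie within the scatter, as does a 1.2-fold lower number from compound 1 to compound 2 (0.07 log units; within the scatter). The three compounds share one core and differ only in the group on the sulfonamide nitrogen, and none of those exchanges has moved the number.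

Compound 4 `Cc1ccnc(NS(=O)(=O)c2ccc(N/C(S)=N\c3ccnc4cc(C(F)(F)F)ccc34)cc2)n1` carries the change (4-methylpyrimidin-2-yl in place of pyridin-2-yl on a sulfonamide nitrogen). This is again an exchange on the sulfonamide nitrogen, the same place varied in the steps from compound 1 to compound 3 and from compound 2 to compound 3, which were both flat. On that basis no step beyond the scatter is expected in this assay for compound 4; the expected step is a 1.0-fold lower number from compound 3 to compound 4 (0.02 log units; within the scatter). Compound 4 is estimated at 27000 nM, with a range from 13000 nM to 55000 nM.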

Compound 4, half-maximal inhibitory concentration: 28700 nM
Compound 4: the middle estimate sits 1.1-fold (0.03 log units) below what was measured; low and high end bracket the measured number.
By their numbers in this assay, from the lowest: compounds 2, 3, 1 and 4 (each within the scatter of the next).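

Replacing pyridin-2-yl with 4-methylpyrimidin-2-yl on a sulfonamide nitrogen (a 1.0-fold higher number from compound 3 to compound 4 (0.01 log units; within the scatter)) shows that this position also stays flat in this assay. Set against acetyl (a 1.0-fold higher number from compound 1 to compound 4 (0.01 log units; within the scatter)) and against the group of 3 heavy atoms with no ring (a 1.2-fold higher number from compound 2 to compound 4 (0.07 log units; within the scatter)), the entering group also stays within the scatter, so ring and non-ring groups on this nitrogen cannot be told apart among these four compounds. No available evidence bears on this result.

Going by these compounds, whether a free amine or a carboxylic acid on a longer chain at this nitrogen would move the number in this assay remains open. Also open, on these data alone, is whether replacing the trifluoromethyl with a chlorine elsewhere on the shared core would do so.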